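A few compounds are considered here, and "the series" means these few. Any claim that something is new, unique, unknown or untested is made for them only; others in the source may bear on it.

Of the compounds shown here, three built on one shared core have been measured in a functional assay on PC-3 cells (Homo sapiens) for inhibition, read by sulforhodamine B assay, with a stated time of 72 h; on this read-out higher numbers stand for weaker inhibition and lower numbers for stronger inhibition. Compound 1 `Nc1sc(-c2ccc(Cl)cc2)c(-c2ccc(Cl)cc2)c1C(=O)NC1CC1` gives 3680 nM, compound 2 `CC1CN(C(=O)c2c(N)sc(-c3ccc(Cl)cc3)c2-c2ccc(Cl)cc2)CCN1` gives 7210 nM, and compound 3 `CC1CCN(C(=O)c2c(N)sc(-c3ccc(Cl)cc3)c2-c2ccc(Cl)cc2)CC1` gives 5750 nM. On these numbers compound 3 holds the second highest place of the three, yet every step among them stays within the scatter: a 1.6-fold higher number from compound 1 to compound 3 (0.19 log units; within the scatter) and a 1.3-fold lower number from compound 2 to compound 3 (0.10 log units; within the scatter), as well as a 2.0-fold higher number from compound 1 to compound 2 (0.29 log units; within the scatter). Compound 4 `CC(C)CNC(=O)c1c(N)sc(-c2ccc(Cl)cc2)c1-c1ccc(Cl)cc1` differs from compound 3 in that (isobutylamino in place of 4-methylpiperidin-1-yl on a carbonyl carbon). The step that bears most on this exchange of a ring amine for a small open-chain amino group is a 1.6-fold higher number from compound 1 to compound 3 (0.19 log units; within the scatter), and it was small. Compound 4 is therefore expected to show a step of a 1.4-fold lower number from compound 3 to compound 4 (0.14 log units; within the scatter), nothing beyond the scatter. Compound 4 is estimated at 4200 nM, with a range from 2000 nM to 9000 nM.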

Compound 4, half-maximal inhibitory concentration: 13200 nM
For compound 4 the middle estimate is 3.1-fold (0.50 log units) below the measured one, outside the stated range (above it).
By their numbers in this assay, from the lowest: compounds 1, 3, 2 and 4 (each within the scatter of the next, the first and the last beyond it).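

In this assay, within the data shown here, isobutylamino on the carbonyl carbon gives the first steps of this set beyond the scatter, with a 2.3-fold higher number from compound 3 to compound 4 (0.36 log units; beyond the scatter) and a 3.6-fold higher number from compound 1 to compound 4 (0.55 log units; beyond the scatter) while a 1.8-fold higher number from compound 2 to compound 4 (0.26 log units; within the scatter) stays within it. The group on this carbonyl carbon can therefore move the number, and isobutyl and cyclopropyl on the amide-type nitrogen stand at the two ends of the series. No measurement given here accounts for this difference. The compounds shown leave open whether a longer chain, a benzyl group or a hydroxyethyl group on that nitrogen would lie nearer isobutyl or cyclopropyl, and where a morpholine ring would fall.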